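This account rests on a few compounds, and the source may have more. Where it says the series, first, only, none or still open, it means among the compounds named here.

Measured in an ADME assay on microsomes from liver (Homo sapiens) for metabolic stability; on this read-out higher numbers stand for fast clearance and lower numbers for slow clearance:
Compound 1 `CC(=O)N[C@@H]1CCC[C@H](C(=O)Nc2cc(-c3cnc(C)n3C(C)C)ccn2)C1`: 3.6 mL.min-1.g-1.
Compound 2 `CC(=O)N[C@@H]1CCC[C@H](C(=O)Nc2cc(-c3cnn4c3CCC4)c(Cl)cn2)C1`: < 3 mL.min-1.g-1, a limit of the assay and not a number.

Compound 2 stands at the limit of < 3 mL.min-1.g-1 in this assay, at which 1 of the 2 values shown sits, so the data give no exact clearance for it. Compound 3 `CC(=O)N[C@@H]1CCC[C@H](C(=O)Nc2cc(-c3cnn4c3COCC4)c(Cl)cn2)C1` has not yet been measured. It keeps the core and the acetamide-bearing part of compound 2 and differs in one place, ortho to a chloro group and opposite the ring nitrogen: a group of 9 heavy atoms (6 carbon, 2 nitrogen, 1 oxygen; one five-membered aromatic ring with 2 hetero atoms, one six-membered non-aromatic ring with 2 hetero atoms) in place of a group of 8 heavy atoms (6 carbon, 2 nitrogen; one five-membered non-aromatic ring with 1 hetero atom, one five-membered aromatic ring with 2 hetero atoms), on an aromatic carbon. The five-membered aromatic ring with 2 hetero atoms stays, while the fused non-aromatic ring changes. Among the measured compounds shown here, no measured pair shows this exchange, so the expectation rests on compound 2 and its < 3 mL.min-1.g-1, which is a limit. No change beyond the usual scatter is expected in this assay. The expected step of a number no lower from compound 2 to compound 3 (the limit leaves the size open) is therefore small. Compound 3 is estimated at 3 mL.min-1.g-1, with an expected range of 2 mL.min-1.g-1 to 6 mL.min-1.g-1, and it may well be reported only as a limit.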

Compound 3, intrinsic clearance in microsomes: < 3 mL.min-1.g-1
Compound 3: no number, only a limit; the forecaster's own chance of this, stated with the estimate: 50%; the middle value sits exactly at the limit.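

In this assay, compound 3 gives < 3 mL.min-1.g-1, a limit of the assay and not a number. Compound 2 also gives only a limit, so no step can be read between compound 2 and compound 3: the limit of < 3 mL.min-1.g-1 in this assay, at which 2 of the 3 values shown sit. The compounds shown leave open the exact clearance of both compounds and whether exchanging the fused non-aromatic ring changes it at all.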